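Side chain change from compound 2 to compound 3

The source may hold more compounds than are shown below. What is called first, only, known or untested is meant among the compounds shown, and "the series" means these compounds.

In a functional assay on MCF7 cells (Homo sapiens) for cytotoxicity, read by MTT assay, with a stated time of 72 h (a higher number here means a weaker inhibitor, a lower number a stronger inhibitor), compound 1 (`COc1ncc(-c2ccc3nc(NC(=O)N(C)C)nn3c2)cc1NS(=O)(=O)c1ccc(F)cc1`) gives 1560 nM, and compound 2 (`COc1ncc(-c2ccc3nc(NC(=O)NCCN4CCCCC4)nn3c2)cc1NS(=O)(=O)c1ccc(F)cc1`) gives 200 nM, the lower of the two numbers. Among the measured compounds shown here, the only measured step is a 7.8-fold lower number from compound 1 to compound 2 (0.89 log units; beyond the scatter), with (2-(piperidin-1-yl)ethyl)amino in place of dimethylamino on a carbonyl carbon. Compound 3 (`COc1ncc(-c2ccc3nc(NC(=O)NCC(=O)N4CCCC4)nn3c2)cc1NS(=O)(=O)c1ccc(F)cc1`) carries (pyrrolidin-1-yl)carbonyl in place of (piperidin-1-yl)methyl on a saturated chain carbon bound to an amide-type nitrogen. For the measured compounds named here, no measured pair shows this exchange, so the step of a 7.8-fold lower number from compound 1 to compound 2 (0.89 log units; beyond the scatter) is only an indirect guide, setting the size of change seen so far at this side chain. Part of that drop is expected to be given back, which points to a moderate move towards a higher number in this assay. The expected change is a 2.8-fold higher number from compound 2 to compound 3 (0.44 log units; beyond the scatter). For compound 3 the estimate is 550 nM, with an expected range of 170 nM to 1800 nM.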

Compound 3, half-maximal inhibitory concentration: 2130 nM
The estimate for compound 3 lay 3.9-fold (0.59 log units) below the measured number; the measured number lies above the stated range.
By their numbers in this assay, from the lowest: compound 2; then compounds 1 and 3 (each within the scatter of the next).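

In this assay the exchange of (piperidin-1-yl)methyl for (pyrrolidin-1-yl)carbonyl gives an 11-fold higher number from compound 2 to compound 3 (1.03 log units; beyond the scatter) and is the largest single change at this side chain so far, so this place on the chain does not tolerate every group of the same heavy-atom count. Set against the dimethylamino urea, the result is a 1.4-fold higher number from compound 1 to compound 3 (0.14 log units; within the scatter) and shows that the gain seen with compound 2 does not follow from a longer side chain ending in a saturated ring alone. The compounds shown carry no evidence that explains this loss.

The step changes ring size and adds a carbonyl at once, and 2-(pyrrolidin-1-yl)ethyl would separate the two. As far as these compounds go, whether the low number of compound 2 depends on the piperidine ring also stays open, and 2-(dimethylamino)ethyl or 2-(morpholin-4-yl)ethyl would test that.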